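The compounds below may be only part of what the source reports. "The series", "measured", "known", "first", "only" and "open" are said of these compounds alone.

Compound 2 `Fc1cccc(-c2nc(Nc3ccc(Br)cc3)c3cc(F)ccc3n2)c1` carries 4-bromophenyl on a nitrogen on an aromatic ring of the shared core. In a functional assay on MDA-MB-231 cells (Homo sapiens) for cytotoxicity, read by MTT assay, with a stated time of 48 h (on this read-out lower numbers stand for stronger inhibition and higher numbers for weaker inhibition), compound 2 gives only a limit of the assay, > 50000 nM. Compound 1 `Fc1cccc(-c2nc(Nc3ccccc3F)c3cc(F)ccc3n2)c1`, which bears 2-fluorophenyl in the same place, returns in this assay only a limit as well, > 50000 nM. For the measured compounds named here, the single step measured so far, a step that the two limits leave unreadable from compound 1 to compound 2, has no readable size, because both of its ends sit at the limit of > 50000 nM in this assay, at which 2 of the 2 values shown sit. Compound 2 therefore stands at the limit of this assay with no numerical value of its own, and nothing in the series separates it from compound 1.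

Compound 3 `Nc1ccc(Nc2nc(-c3cccc(F)c3)nc3ccc(F)cc23)cc1` is the next member and differs from compound 2 in one place: amino in place of bromo on an aromatic carbon. Going by the values given here, no measured step bears on this change; the only step recorded in this assay is itself unreadable, so no direction or size can be drawn from it. The step of a number no higher from compound 2 to compound 3 (the limit leaves the size open) is accordingly expected to stay inside the region the two limits leave undefined. For compound 3 the estimate in this assay is 50000 nM, with a range from 10000 nM to 200000 nM, and a limit rather than a number is the likelier report.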

Compound 3, half-maximal inhibitory concentration: > 50000 nM
Compound 3 was reported as a limit; the forecaster's own chance of this, stated with the estimate: 75%; the middle value sits exactly at the limit.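

No new step can be read from compound 3 to compound 2 or compound 1 in this assay, because all three compounds end the same way: the limit of > 50000 nM in this assay, at which 3 of the 3 values shown sit.

The compounds shown leave open how 2-fluorophenyl, 4-bromophenyl and 4-aminophenyl rank against one another in this assay, and what numerical value any of these compounds would have.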